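Cytotoxicity notes: amide replaced by urea on the shared core

A few compounds are considered here, and "the series" means these few. Any claim that something is new, unique, unknown or untested is made for them only; others in the source may bear on it.

Compound 1 `CCN(CC)c1cc2[nH]c(C3CCCCC3)nc2cc1NC(=O)c1ccc(F)cc1` carries a 4-fluorophenyl on the carbonyl carbon of its amide. In an ADME assay on Vero cells (Chlorocebus sabaeus) for cytotoxicity, read by resazurin assay, with a stated time of 3 days (a lower number here means a stronger inhibitor, a higher number a weaker inhibitor), compound 1 reaches only the assay limit, reported as > 100 ug/mL. Two further members of the series sit in the same place. Compound 2 `Cc1ccc(C(=O)Nc2cc3nc(C4CCCCC4)[nH]c3cc2N2CCCC2)cc1` is reported in this assay as a limit of > 100 ug/mL. Compound 3 `CN(C)c1cc2[nH]c(C3CCCCC3)nc2cc1NC(=O)c1ccc(C(C)(C)C)cc1` likewise gives only a limit, > 100 ug/mL. So far, then, no number exists for any member of the series: every reading sits at the limit of > 100 ug/mL in this assay, at which 3 of the 3 values shown sit, and compound 1 stands level with both of its companions, with nothing to separate them.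

Compound 4 `CCCNC(=O)Nc1cc2nc(C3CCCCC3)[nH]c2cc1N(CC)CC` is the next member to be measured. It differs from compound 1 in one place: propylamino in place of 4-fluorophenyl on a carbonyl carbon. Among the measured compounds shown here, whether this change moves the read-out cannot be read from the measured members, since no step between them carries a number. The expected step in this assay is none beyond the scatter, a step that the limit leaves unreadable from compound 1 to compound 4, because all three measured members sit at the limit of > 100 ug/mL in this assay, at which 3 of the 3 values shown sit. Compound 4 is therefore expected to return 150 ug/mL, with a range from 70 ug/mL to 300 ug/mL, and most likely only a limit once more.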

Compound 4, half-maximal inhibitory concentration: > 100 ug/mL
Compound 4 was reported as a limit (the forecaster's own chance of this, stated with the estimate: 85%); the middle value lies beyond the limit too.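

Compound 4 gives only a limit in this assay, > 100 ug/mL. No step can be read from compound 1 to compound 4, since both readings are limits: the limit of > 100 ug/mL in this assay, at which 4 of the 4 values shown sit.

The compounds shown leave open whether propylamino in place of 4-fluorophenyl on a carbonyl carbon changes the half-maximal inhibitory concentration in this assay at all.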